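The source may report more compounds than this note shows. Statements on the series, on what has been measured and on what is new or still open speak of the compounds shown alone.

Measured in a physicochemical assay for solubility, read by nephelometry, measured as kinetic solubility; a lower number here means a less soluble compound, a higher number a more soluble compound:
- compound 1 `CCC/N=C1\S/C(=C\c2ccc(C(=O)NCC(=O)N(C)C)cc2)C(=O)N1c1ccccc1O`: 219000 nM
- compound 2 `CCC/N=C1\S/C(=C\c2ccc(C(=O)OCC3COC(=O)O3)cc2)C(=O)N1c1ccccc1O`: 79000 nM

Compound 2 holds the lower of these two numbers. For the measured compounds named here, the only measured step, a 2.8-fold lower number from compound 1 to compound 2 (0.44 log units; beyond the scatter), is modest and replaced a whole group on a carbonyl carbon. Compound 3 `CCC/N=C1\S/C(=C\c2ccc(C(=O)OCc3oc(=O)oc3C)cc2)C(=O)N1c1ccccc1O` carries a narrower change from compound 2: a group of 7 heavy atoms (4 carbon, 3 oxygen; one five-membered aromatic ring with 2 hetero atoms) in place of a group of 6 heavy atoms (3 carbon, 3 oxygen; one five-membered non-aromatic ring with 2 hetero atoms), on a saturated chain carbon bound to an oxygen next to a carbonyl group. Going by the values given here, no measured step tests this exact swap, so the step from compound 1 offers only a loose guide to its size. A small move to a lower number is expected, possibly within the scatter. The expected step is a 1.4-fold lower number from compound 2 to compound 3 (0.16 log units; within the scatter). For compound 3 the estimate is 55000 nM, with an expected range of 20000 nM to 130000 nM.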

Compound 3, solubility: 79000 nM
Compound 3: the middle estimate sits 1.4-fold (0.16 log units) below what was measured; low and high end bracket the measured number.
By their numbers in this assay, from the lowest: compounds 2 and 3 (each within the scatter of the next); then compound 1.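

In this assay, putting the aromatic ring group in place of the 2-oxo-1,3-dioxolan-4-yl group on this saturated chain carbon gives no change at the digits printed from compound 2 to compound 3 (within the scatter), so a non-aromatic and an aromatic five-membered ring read alike here. The step of a 2.8-fold lower number from compound 1 to compound 3 (0.44 log units; beyond the scatter) is the same size as the step to compound 2. No measurement here bears on why the two rings read alike. From the compounds shown here alone, whether a group without a ring at this place, such as a plain ethyl chain or a chain carrying an amine, would also read alike remains open.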